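Replacing phenyl with chloromethyl on a carbonyl carbon

The compounds below may be only part of what the source reports. "The series", "measured", "known", "first", "only" and "open" are said of these compounds alone.

Measured in a functional assay on cells (Homo sapiens) for inhibition, read by MTT assay, with a stated time of 72 h; on this read-out higher numbers stand for weaker inhibition and lower numbers for stronger inhibition:
Compound 1 `O=C(O)Cn1ncc2c(Nc3ccc(NS(=O)(=O)c4ccccc4)cc3)ncnc21`: > 100 ug/mL (a limit)
Compound 2 `O=C(O)Cn1ncc2c(Nc3ccc(NC(=O)c4ccccc4)cc3)ncnc21`: > 100 ug/mL (a limit)

Compound 2 stands at a limit and not at a number: in this assay compound 2 gives > 100 ug/mL. Within the data shown here, the only other value shown is also a limit, so nothing places compound 2 more exactly. Compound 3 `O=C(O)Cn1ncc2c(Nc3ccc(NC(=O)CCl)cc3)ncnc21` differs from compound 2 by one exchange: chloromethyl in place of phenyl on a carbonyl carbon. In words, this is chloromethyl in place of phenyl on a carbonyl carbon.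

Among the measured compounds shown here, one measured step bears on it, and only loosely: a step that the two limits leave unreadable from compound 1 to compound 2. That step is benzoyl in place of phenylsulfonyl on a nitrogen on an aromatic ring, so it concerns a different exchange, and it has no readable size. The whole record is the limit of > 100 ug/mL in this assay, at which 2 of the 2 values shown sit. For the measured compounds named here, no measured step therefore sets a size for this exchange. Compound 3 is expected to stay weak in this assay, possibly at the same limit, with a modest move towards stronger inhibition possible. The expected change is an at least 1.2-fold lower number from compound 2 to compound 3 (0.09 log units; that floor lies within the scatter). Compound 3 is estimated at 80 ug/mL, with an expected range from 20 ug/mL to 200 ug/mL.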

Compound 3, half-maximal inhibitory concentration: > 100 ug/mL
Compound 3 gave a limit, no number; the forecaster's own chance of this, stated with the estimate: 55%; middle value at least 1.2-fold (0.09 log units) away from the limit.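

In this assay, among these compounds, compound 3 gives > 100 ug/mL, which is a limit and not a number, so no step among compound 1, compound 2 and compound 3 can be read. The record for the three compounds is a single limit: the limit of > 100 ug/mL in this assay, at which 3 of the 3 values shown sit. The compounds shown leave open how strongly any of them inhibits, and whether any of these exchanges moves the read-out at all.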